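Swapping the acidic tail of compound 2

A few compounds are considered here, and "the series" means these few. Any claim that something is new, unique, unknown or untested is made for them only; others in the source may bear on it.

Measured so far in an assay on isolated protein for agonist activity at Bile acid receptor (Homo sapiens), read by FRET; on this read-out higher numbers stand for an effect only at larger amounts of compound and lower numbers for an effect already at smaller amounts:
compound 1, `O=C(O)c1cccc([C@H]2C[C@@H](c3ccc(OCc4c(-c5c(Cl)cccc5Cl)noc4C4CC4)cc3Cl)C2)c1`: 77 nM
compound 2, `CS(=O)(=O)NC(=O)c1ccc(C2CC2c2ccc(OCc3c(-c4c(Cl)cccc4Cl)noc3C3CC3)cc2Cl)cc1`: 90 nM
compound 3, `O=C(O)c1cncc(N2CC(O)(c3ccc(OCc4c(-c5c(Cl)cccc5Cl)noc4C4CC4)cc3Cl)C2)c1`: 7 nM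

Compound 2 stands at the highest of the three numbers. Compound 1 sits within the scatter of it, so the two cannot be told apart in this assay. Compound 3 lies well beyond the scatter, with a markedly lower number than compound 2.

Compound 4, `O=C(O)CNC(=O)c1ccc(C2CC2c2ccc(OCc3c(-c4c(Cl)cccc4Cl)noc3C3CC3)cc2Cl)cc1`, differs from compound 2 in one place: carboxymethyl in place of methylsulfonyl on an amide-type nitrogen. For the measured compounds named here, no measured pair shows this change, so the size of the step is open. Because compound 1 with its own acid gives 77 nM, close to compound 2, no step beyond the scatter is expected; the estimated step is a 1.3-fold higher number from compound 2 to compound 4 (0.12 log units; within the scatter). Compound 4 is therefore expected near 120 nM, between 40 nM and 400 nM.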

Compound 4, half-maximal effective concentration: 150 nM
Beside the measured number, compound 4's estimate is 1.3-fold (0.10 log units) below it; the measured number falls inside the stated range.
By their numbers in this assay, from the lowest: compound 3; then compounds 1, 2 and 4 (each within the scatter of the next).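

In this assay, putting carboxymethyl in place of methylsulfonyl on the amide-type nitrogen gives a 1.7-fold higher number from compound 2 to compound 4 (0.22 log units; within the scatter), so the two groups cannot be told apart at this position. For the compounds shown here, this pair is the first to differ in one place, and it shows that this position accepts either group with no step beyond the usual scatter. Nothing available here accounts for the result. From the compounds shown here alone, what a longer chain such as carboxyethyl, or an aminoethyl group, would do on this nitrogen stays open. So does the effect of a plain methyl there.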